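This account rests on a few compounds, and the source may have more. Where it says the series, first, only, none or still open, it means among the compounds named here.

Measured so far in an assay on isolated protein for inhibition of calcium/calmodulin-dependent protein kinase type II subunit alpha (Homo sapiens), read by HTRF, tested at 10 uM; a higher number here means more inhibition at the concentration tested (going by the name of the read-out), a lower number less inhibition:
compound 1 `CN(CCCn1ccnc1)C(=O)[C@@H]1CCCN1c1nccc(Nc2ccccc2)n1` gives 0%
compound 2 `CC(=O)CCCCC(=O)N1CCN(c2nccc(Oc3cccc(C)c3)n2)CC1` gives 0%
compound 3 `Cc1cc(C(=O)N2CCN(c3ncnc4c3CN(Cc3ccccc3)CC4)CC2)c(C)n1C` gives 0%

Compound 1 stands level with compounds 2 and 3 at the digits shown; the nearest is compound 2 and the furthest compound 3, neither differing from it beyond the scatter. Among the compounds with values here, no pair among the three differs in a single place, so no step between measured compounds is on record.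

Compound 4 `CN(C)CC(C)(C)CNC(=O)[C@@H]1CCCN1c1nccc(Nc2ccccc2)n1` carries (2-((dimethylamino)methyl)-2-methylpropyl)amino in place of (3-(1H-imidazol-1-yl)propyl)(methyl)amino on a carbonyl carbon. All three measured values show no inhibition at the concentration tested, and nothing measured tells how a change on the carbonyl carbon moves the read-out in this assay. The step from compound 1 to compound 4 is expected to be a number 3 percentage points higher from compound 1 to compound 4 (within the scatter), none beyond the scatter. Compound 4 is expected to give 3%, within -8% to 15%.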

Compound 4, a percentage reported as inhibition, at one concentration (the size of the read-out at that concentration, not a potency): 0%
The estimate for compound 4 lay 3 percentage points above the measured number, within the range that was stated.
By their numbers in this assay, from the lowest: compounds 1, 2, 3 and 4 (each within the scatter of the next).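

In this assay, within the data shown here, the first step on record at this position reads no change at the digits printed from compound 1 to compound 4 (within the scatter) on replacing (3-(1H-imidazol-1-yl)propyl)(methyl)amino with (2-((dimethylamino)methyl)-2-methylpropyl)amino on a carbonyl carbon. Removing the five-membered aromatic ring and adding a hydrogen-bond donor therefore leaves no mark on this read-out. Nothing on record bears on why. From the compounds shown here alone, with no inhibition on either side of the step, it remains open whether any group on this carbonyl carbon can produce a reading. A carboxylic acid or a longer chain carrying a primary amine there would test this.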